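Cytotoxicity notes on a nitrobenzamide series, outlook for compound 4

The source may hold more compounds than are shown below. What is called first, only, known or untested is meant among the compounds shown, and "the series" means these compounds.

Measured so far:
compound 1 `O=C(Nc1cc(-c2nc3ccccc3s2)ccc1Cl)c1cc([N+](=O)[O-])ccc1Cl`: > 25000 nM
compound 2 `O=C(Nc1nc(-c2ccc(Cl)cc2)cs1)c1cc([N+](=O)[O-])ccc1Cl`: 12000 nM
compound 3 `COc1cc(Cl)c(C(=O)Nc2cccc(-c3nc4ccccc4s3)c2)cc1[N+](=O)[O-]`: > 25000 nM

In an ADME assay on Raji cells (Homo sapiens) for cytotoxicity, with a stated time of 72 h (a higher number here means that more compound is needed for the effect, a lower number that less compound is needed), compound 1 gives > 25000 nM, which is a limit of the assay and not a number. Compound 3 likewise gives only a limit in this assay, at > 25000 nM. Compound 2 gives a measured value in this assay, 12000 nM. Compound 1 therefore stands at the limit of > 25000 nM in this assay, at which 2 of the 3 values shown sit, and no rank order against compound 3 can be drawn from two limits.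

Within the data shown here, no two measured compounds differ in one place, so no step size in this assay is known from the data.

Compound 4, `Cc1ccc(-c2nc3ccccc3s2)cc1NC(=O)c1cc([N+](=O)[O-])ccc1Cl`, differs from compound 1 by methyl in place of chloro on an aromatic carbon. Without a measured step to lean on, the change from compound 1 to compound 4 is expected to stay within the scatter, so the estimated step is a number no higher from compound 1 to compound 4 (the limit leaves the size open). For compound 4 the estimate in this assay is 25000 nM, with an expected range from 10000 nM to 60000 nM, and a limit rather than a number is the likelier outcome.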

Compound 4, half-maximal effective concentration: > 14000 nM
Compound 4 ended at the assay's limit; the forecaster's own chance of this, stated with the estimate: 60%; the middle value does not contradict the limit.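

In this assay no step can be read from compound 1 to compound 4, as both values are limits of the assay and not numbers. The compounds shown leave open whether methyl in place of chloro on an aromatic carbon changes the value in this assay at all.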